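A few compounds are considered here, and "the series" means these few. Any claim that something is new, unique, unknown or untested is made for them only; others in the source may bear on it.

Measured so far:
compound 1, `CSc1nc(NCCCCc2ccccc2)c2ccccc2n1`: > 100000 nM
compound 2, `CSc1nc(NCCCCCO)c2ccccc2n1`: 99400 nM

Among the measured compounds shown here, in an ADME assay on BEAS-2B cells (Homo sapiens) for cytotoxicity, read by MTT assay, with a stated time of 72 h (a lower number here means a stronger inhibitor of growth, a higher number a weaker inhibitor of growth), compound 2 gives 99400 nM, the only numerical value shown. For compound 1 the value of > 100000 nM is a limit of the assay rather than a number. Compound 2 thus stands as the single measured point, with only a limit beside it. Compound 3, `CSc1nc(Nc2ccccc2)c2ccccc2n1`, is not yet measured in this assay; it differs from compound 2 by phenyl in place of 5-hydroxypentyl on a nitrogen on an aromatic ring. For the measured compounds named here, the only measured step, a number no higher from compound 1 to compound 2 (the limit leaves the size open), likewise exchanges a phenyl for a hydroxyl-bearing end, though there on a chain carbon, and its size cannot be read because one of its values sits at the limit of > 100000 nM in this assay, at which 1 of the 2 values shown sits. That step gives little guidance, and both values lie at the weak end of the scale. Compound 3 is expected to stay in the same region, with an estimated step of a 1.1-fold lower number from compound 2 to compound 3 (0.04 log units; within the scatter) that may well return only a limit. Compound 3 is therefore estimated at 90000 nM, with a range from 40000 nM to 200000 nM.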

Compound 3, concentration for total growth inhibition: > 100000 nM
Compound 3: only a limit was reported; the forecaster's own chance of this, stated with the estimate: 50%; middle value at least 1.1-fold (0.04 log units) from the limit.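

In this assay compound 3 gives > 100000 nM, which is a limit of the assay and not a number. At this position, on a nitrogen on an aromatic ring, a phenyl set directly on the nitrogen therefore gives no numerical value, as the phenyl at the end of the chain in compound 1 also gave only a limit. Phenyl in place of 5-hydroxypentyl gives a number no lower from compound 2 to compound 3 (the limit leaves the size open) on this nitrogen. Neither step among these compounds can be read, so the size of this change stays unknown: the limit of > 100000 nM in this assay, at which 2 of the 3 values shown sit.

As far as these compounds go, whether an amine or a carboxylic acid at the end of the pentyl chain would give a clearly lower number than compound 2 stays open. So does the question of whether a benzyl group on the same nitrogen would give a number at all in this assay.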